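This account rests on a few compounds, and the source may have more. Where it says the series, first, only, none or still open, it means among the compounds named here.

Of the compounds shown here, three from this series have been measured in a functional assay on MGC-803 cells (Homo sapiens) for inhibition, read by sulforhodamine B assay; a lower number here means a stronger inhibitor, a higher number a weaker inhibitor. Compound 1 `COc1cccc(NC2=CC(=O)c3c(nc4n3[C@H]3OC[C@@H](O)[C@H]3OC4)C2=O)c1` gives 1790 nM. Compound 2 `O=C1C=C(Nc2ccc(C(F)(F)F)cc2)C(=O)c2c1nc1n2[C@H]2OC[C@@H](O)[C@H]2OC1`, which carries a trifluoromethyl group on the aniline ring, gives 2820 nM, the higher of the two numbers, though it sits within the scatter of compound 1. Compound 3 `O=C1C(NC2CCCCC2)=CC(=O)c2c1nc1n2[C@H]2OC[C@@H](O)[C@H]2OC1` gives > 8000 nM, which is a limit of this assay rather than a number. Going by the values given here, the one change measured as a single step, cyclohexyl in place of 3-methoxyphenyl on an amine nitrogen, weakens inhibition by an at least 4.4-fold higher number from compound 1 to compound 3 (0.65 log units; beyond the scatter).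

The next compound, compound 4 `O=C1C=C(Nc2ccc(Br)cc2)C(=O)c2c1nc1n2[C@H]2OC[C@@H](O)[C@H]2OC1`, differs from compound 2 in one place: bromo in place of trifluoromethyl on an aromatic carbon. Among the compounds with values here, no measured step in this assay swaps one substituent on the aniline ring for another; the only measured step exchanges the whole aromatic ring for a saturated one, which is a different kind of change. There is therefore no measured ground for expecting a shift beyond the scatter, and the value of compound 4 is expected to stay close to that of compound 2, a step of a 1.1-fold lower number from compound 2 to compound 4 (0.05 log units; within the scatter). Compound 4 is estimated at 2500 nM, with a range from 1000 nM to 6500 nM.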

Compound 4, half-maximal inhibitory concentration: 1010 nM
Beside the measured number, compound 4's estimate is 2.5-fold (0.39 log units) above it; low and high end bracket the measured number.
By their numbers in this assay, from the lowest: compounds 4, 1 and 2 (each within the scatter of the next, the first and the last beyond it). At a limit, above all of these: compound 3.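

Going by these compounds alone, until now, no measured step had changed only the substituent on the aniline ring, as the one earlier step replaced the whole aromatic ring with a saturated one. In this assay, replacing trifluoromethyl with bromo on an aromatic carbon, para to a large group, gives a 2.8-fold lower number from compound 2 to compound 4 (0.45 log units; beyond the scatter) and so shows that this position responds to the choice of substituent, with a single bromine atom in place of a group of four heavy atoms moving the number toward stronger inhibition. Nothing measured for these compounds explains why this exchange shifts the number, so the step stands as an observation without a stated cause.

Going by these compounds, with only trifluoromethyl and bromo compared directly at this position, it remains open whether bromo is unusual or whether other groups, such as chloro, an amine or a carboxylic acid, would give similar or quite different numbers. On these data alone, it also remains open whether the same exchange would produce a step of similar size on a different carbon of the ring or with a different core.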